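The source may hold more compounds than are shown below. What is called first, only, known or untested is meant among the compounds shown, and "the series" means these compounds.

Three related compounds have so far been tested in a functional assay on HepG2 cells (Homo sapiens) for antiproliferative activity, read by MTT assay, with a stated time of 48 h; on this read-out lower numbers stand for stronger inhibition and higher numbers for weaker inhibition. Compound 1 `COc1ccccc1/C=C/C(=O)c1nc2ccccc2[nH]1` gives 7990 nM in this assay, and compound 3 `COc1cccc(/C=C/C(=O)c2nc3ccccc3[nH]2)c1` gives 5680 nM in this assay. Compound 2 `COc1cccc(/C=C/C(=O)c2nc3ccccc3s2)c1` stands apart from these two, because its result in this assay is only a limit, > 100000 nM, and not a number. Among the three values shown, compound 2 therefore sits at the limit of > 100000 nM in this assay, at which 1 of the 3 values shown sits, while compound 1 and compound 3 both return measured numbers.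

The step in question leads from compound 2 to compound 4 `O=C(/C=C/c1cccc(Cl)c1)c1nc2ccccc2s1`. Computed from the two structures, the change is chloro in place of methoxy on an aromatic carbon. The core of compound 2 is kept, and only the substituent on the pendant ring is exchanged.

Among the compounds with values here, no measured step between two compounds is available here, so the size of this change can only be estimated. Since compound 2 itself gave no number in this assay, the step from compound 2 to compound 4 is expected to be small, with compound 4 remaining weak and the expected step being an at least 1.1-fold lower number from compound 2 to compound 4 (0.04 log units; that floor lies within the scatter). For compound 4 the estimated value in this assay is 90000 nM, with a range from 20000 nM to 300000 nM, and it is likely that this assay will again report only a limit.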

Compound 4, half-maximal inhibitory concentration: > 100000 nM
Compound 4 ended at the assay's limit; the forecaster's own chance of this, stated with the estimate: 60%; middle value at least 1.1-fold (0.04 log units) away from the limit.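

Compound 2 and compound 4 both end at a limit in this assay, not at a number, so the step between them cannot be read: the limit of > 100000 nM in this assay, at which 2 of the 4 values shown sit.

The compounds shown leave open whether chloro in place of methoxy on an aromatic carbon changes the read-out at all, and how far either compound lies past that limit.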